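This account rests on a few compounds, and the source may have more. Where it says the series, first, only, none or still open, it means among the compounds named here.

Measured compounds:
compound 1 `CCCCCNc1ncnc2c1ncn2[C@@H]1O[C@H](CO)[C@@H](O)[C@H]1O`, in an assay on isolated protein for binding affinity to Equilibrative nucleoside transporter 1 (Homo sapiens) (on this read-out higher numbers stand for weaker inhibition and lower numbers for stronger inhibition), compound 1 gives 13500 nM
compound 2 `OC[C@H]1O[C@@H](n2cnc3c(CSc4ccccc4I)ncnc32)[C@H](O)[C@@H]1O`, in this assay compound 2 gives 282 nM

Compound 2 stands lowest of the two numbers measured; the only shown step, a 48-fold lower number from compound 1 to compound 2 (1.68 log units; beyond the scatter), separates it from compound 1. Compound 3 `COc1ccc(SCc2ncnc3c2ncn3[C@@H]2O[C@H](CO)[C@@H](O)[C@H]2O)cc1` has not yet been measured. It differs from compound 2 in one place: 4-methoxyphenyl in place of 2-iodophenyl on a sulfur. Among the compounds with values here, no measured step touches this change, since the step from compound 1 to compound 2 exchanges a different group and the shared core is unchanged throughout. With nothing in the data to show what an exchange of one aromatic group for another on the sulfur does, compound 3 is expected to stay close to compound 2, and the expected step of a 1.8-fold higher number from compound 2 to compound 3 (0.25 log units; within the scatter) is within or only a little beyond the scatter. For compound 3 the estimate in this assay is 500 nM, with a range from 150 nM to 2000 nM.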

Compound 3, half-maximal inhibitory concentration: 617 nM
Beside the measured number, compound 3's estimate is 1.2-fold (0.09 log units) below it; the range from low to high includes it.
By their numbers in this assay, from the lowest: compound 2; then compound 3; then compound 1.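

In this assay, 4-methoxyphenyl in place of 2-iodophenyl on the sulfur gives a 2.2-fold higher number from compound 2 to compound 3 (0.34 log units; beyond the scatter), a modest step. Within the data shown here, this is the first view of an exchange on the far side of the sulfur, and it shows that a number of the same order is kept when the iodine gives way to a methoxy group, although the two compounds remain separated beyond the scatter. Nothing available explains the difference between these two groups.

The names show that both the substituent and its place on the phenyl ring change in this one step, so 4-iodophenyl or 2-methoxyphenyl would be needed to tell those two changes apart. From the compounds shown here alone, whether an unsubstituted phenyl, or a phenyl carrying an amine or a carboxylic acid, would keep a similar number also remains open.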